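Methyl addition and microsomal stability in the series

A few compounds are considered here, and "the series" means these few. Any claim that something is new, unique, unknown or untested is made for them only; others in the source may bear on it.

Measured so far:
compound 1 `COC(=O)Nc1cc(-c2ccc(OC[C@@](C)(N)CC(C)C)c(C)c2)ccn1`: 96%
compound 2 `COC(=O)Nc1cc(-c2ccc(OC[C@@](C)(N)CC(C)C)nc2)ccn1`: 96%
compound 3 `COC(=O)Nc1cc(-c2ccc(OC[C@@](C)(N)CC(C)C)c(C)c2C)ccn1`: 83%

In an ADME assay on microsomes from liver (Rattus norvegicus) for metabolic stability, read by LC-MS, using NADPH, with a stated time of 10 min, tested at 0.5 uM (a lower number here means that less of the compound is left, a higher number that more of the compound is left), compound 1 gives 96% and compound 3 gives 83%. The change from compound 1 to compound 3 is methyl in place of hydrogen on an aromatic carbon and its step is a number 13 percentage points lower from compound 1 to compound 3 (beyond the scatter). Compound 2 gives 96% in this assay, level with compound 1 at the digits printed and within the scatter of it; the difference between the two cores of compound 1 and compound 2 is not broken down here.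

Compound 4 `COC(=O)Nc1cc(-c2cnc(OC[C@@](C)(N)CC(C)C)cc2C)ccn1` has not yet been measured. It differs from compound 2 by methyl in place of hydrogen on an aromatic carbon, the same kind of change as from compound 1 to compound 3, though the surroundings differ: in compound 3 the methyl enters on a six-membered aromatic ring of carbon only, ortho to a methyl group, whereas in compound 4 it enters on a ring with one nitrogen, opposite the ring nitrogen, with no methyl group ortho to it.

Resting on the step from compound 1 to compound 3 of a number 13 percentage points lower from compound 1 to compound 3 (beyond the scatter), the step from compound 2 to compound 4 is expected to be a number 11 percentage points lower from compound 2 to compound 4 (beyond the scatter). Compound 4 is therefore estimated at 85% in this assay, with a range from 70% to 96%.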

Compound 4, percent of the compound remaining: 87%
Compound 4: the middle estimate sits 2 percentage points below what was measured, within the range that was stated.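

In this assay the new step on the core of compound 2 is a number 9 percentage points lower from compound 2 to compound 4 (within the scatter), so on this core the methyl in place of hydrogen on an aromatic carbon cannot be told apart from no change. Set beside the earlier step, the two cores show no measurable difference for this change: the same change on two cores in this assay, a number 13 percentage points lower (beyond the scatter) from compound 1 to compound 3 and a number 9 percentage points lower (within the scatter) from compound 2 to compound 4, 4 percentage points apart, within the scatter of two such steps

Among the compounds shown here, this does not establish a fixed size for the step: there are only two pairs, one step lies beyond the scatter and the other within it, and the place of the methyl is not the same, with the methyl of compound 4 opposite the ring nitrogen.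

The compounds shown leave open how other groups at this carbon would read in this assay, for example an ethyl, a methoxy group or a chlorine. They also leave open whether the step would hold with the (2-amino-2,4-dimethylpentyl)oxy group replaced by a shorter chain.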